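A few compounds are considered here, and "the series" means these few. Any claim that something is new, unique, unknown or untested is made for them only; others in the source may bear on it.

Of the compounds shown here, two built on a shared core have been measured in a functional assay (Sus scrofa) with sulfonylurea receptors; K-ATP channels (Homo sapiens) as the target; a higher number here means a larger maximal response, a lower number a smaller maximal response. Compound 1 `CC(C)=CC(=O)Nc1c(C(O)(C(F)(F)F)C(F)(F)F)ccc2ccccc12` gives 96% in this assay, and compound 2 `O=C(Nc1c(C(O)(C(F)(F)F)C(F)(F)F)ccc2ccccc12)c1cccc(Cl)c1` gives 84%. Going by the values given here, compound 2 thus stands as the lower of the two numbers, the only known step being a number 12 percentage points lower from compound 1 to compound 2 (beyond the scatter). Compound 3 `N#Cc1cccc(C(=O)Nc2c(C(O)(C(F)(F)F)C(F)(F)F)ccc3ccccc23)c1` differs from compound 2 at a single place: cyano in place of chloro on an aromatic carbon. Among the compounds with values here, no measured step exchanges one substituent for another on the 3-chlorophenyl group; the one step known replaced the whole 2-methylprop-1-en-1-yl group with 3-chlorophenyl and was modest. The exchange of chloro for cyano is a smaller alteration than that, so the step expected in this assay is a number 2 percentage points lower from compound 2 to compound 3 (within the scatter), close to none beyond the scatter. Compound 3 is accordingly estimated at 82%, with a range from 65% to 98%.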

Compound 3, largest response reached (reported as efficacy), in percent of the reference or control that the assay uses: 96%
Compound 3: the middle estimate sits 14 percentage points below what was measured, and the stated range covers the measured number.
By their numbers in this assay, from the lowest: compound 2; then compounds 1 and 3 (each within the scatter of the next).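

In this assay, going by these compounds alone, the aromatic carbon carrying chloro proves sensitive to its substituent: with one heavy atom leaving and two entering, cyano in place of chloro gives a number 12 percentage points higher from compound 2 to compound 3 (beyond the scatter), a step as large as the one printed for the exchange of the whole 2-methylprop-1-en-1-yl group for 3-chlorophenyl. The lower number of compound 2 therefore does not hold for both phenyl groups shown, since 3-cyanophenyl in place of 2-methylprop-1-en-1-yl gives no change at the digits printed from compound 1 to compound 3 (within the scatter). Nothing measured here explains why chloro and cyano part in this way.

The compounds shown leave open how fluoro, methoxy or an amine would stand at this place. They also leave open whether cyano in place of chloro would give a similar step on another carbon of the same ring.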